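A few compounds are considered here, and "the series" means these few. Any claim that something is new, unique, unknown or untested is made for them only; others in the source may bear on it.

In an assay for displacement of a labelled ligand from Sigma non-opioid intracellular receptor 1 (Cavia porcellus), read by scintillation counting, with a stated time of 180 min (a lower number here means a stronger inhibitor, a higher number a weaker inhibitor), compound 3 `CCCCCN1CCC2(CC1)OC(OC)Cc1c2cnn1-c1ccccc1` gives 0.82 nM, the lowest of the three numbers measured; compound 1 `COC1Cc2c(cnn2-c2ccccc2)C2(CCN(CCCc3ccccc3)CC2)O1` gives 3.2 nM, and compound 2 `COC1Cc2c(cnn2-c2ccccc2)C2(CCN(CC(C)C)CC2)O1` gives 6.3 nM. Compound 4 `C=C(C)CCN1CCC2(CC1)OC(OC)Cc1c2cnn1-c1ccccc1` has not yet been measured; it carries 1-methylethenyl in place of propyl on a saturated chain carbon, two bonds along the chain from an amine nitrogen in a ring, a branched chain holding a double bond in place of a straight one. Within the data shown here, no measured step makes exactly this change. The nearest guides are a 7.7-fold lower number from compound 2 to compound 3 (0.89 log units; beyond the scatter), where a longer straight chain bound to the amine nitrogen in a ring gave the lower number, and the weaker a 3.9-fold lower number from compound 1 to compound 3 (0.59 log units; beyond the scatter). Moving back toward a branched chain is therefore expected to raise the number by a modest amount, an estimated 2.4-fold higher number from compound 3 to compound 4 (0.39 log units; beyond the scatter). Compound 4 is expected to give about 2 nM, between 0.8 nM and 5 nM, in this assay.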

Compound 4, inhibition constant: 1.6 nM
Compound 4: the middle estimate sits 1.3-fold (0.10 log units) above what was measured; the range from low to high includes it.
By their numbers in this assay, from the lowest: compounds 3, 4, 1 and 2 (each within the scatter of the next, the first and the last beyond it).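

Swapping propyl for 1-methylethenyl at this position, two bonds along the chain from the ring amine nitrogen, stays within the scatter, with a 2.0-fold higher number from compound 3 to compound 4 (0.29 log units; within the scatter), so a branched chain holding a double bond can stand here. The same holds for 1-methylethenyl in place of benzyl, with a 2.0-fold lower number from compound 1 to compound 4 (0.30 log units; within the scatter). By contrast, 2-methylprop-2-en-1-yl in place of isopropyl goes beyond it, with a 3.9-fold lower number from compound 2 to compound 4 (0.60 log units; beyond the scatter).

Nothing shown gives a reason for these results. Also open, as far as these compounds go, is how the branch and the double bond each count alone, and how a chain ending in an amine or a hydroxyl would read.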